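A pyridine in place of the methylisoxazole

A few compounds are considered here, and "the series" means these few. Any claim that something is new, unique, unknown or untested is made for them only; others in the source may bear on it.

Measured compounds:
- compound 1 `Cc1cc(-c2c(CCc3ccccc3)c3cc(OCC(=O)NC(C)(C)c4ccccc4)ccc3[nH]c2=O)on1`: 12 nM
- compound 2 `O=C(COc1ccc2[nH]c(=O)c(-c3nccs3)c(CCc3ccccc3)c2c1)NC1(c2ccccc2)CC1`: 13 nM
- compound 3 `Cn1c(=O)c(S(C)(=O)=O)c(CCc2ccccc2)c2cc(OCC(=O)NCc3ccc(Cl)c(Cl)c3)ccc21`: > 10000 nM

Of the compounds shown here, three built on the shared core have been tested in an assay on CHO-K1 cells for displacement of a labelled ligand from adenosine receptor A1 (Homo sapiens), with a stated time of 2 h; on this read-out lower numbers stand for stronger inhibition and higher numbers for weaker inhibition. Compound 1 gives 12 nM, and compound 2 gives 13 nM; the two numbers lie within the usual scatter of each other, so compound 1 holds the lower of the two without being separable from compound 2. Compound 3 gives only a limit of the assay, > 10000 nM, which is the limit of > 10000 nM in this assay, at which 1 of the 3 values shown sits. Compound 3 differs from the others in several places at once, so its limit cannot be tied to any single change.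

Compound 4 `CC(C)(NC(=O)COc1ccc2[nH]c(=O)c(-c3cccnc3)c(CCc3ccccc3)c2c1)c1ccccc1` has not yet been measured. It differs from compound 1 in one place: pyridin-3-yl in place of 3-methyl-1,2-oxazol-5-yl on an aromatic carbon. Compound 2 carries a different five-membered heteroaromatic group at the same place and gives 13 nM, close to compound 1, which suggests that this position accepts varied aromatic groups. A pyridine is a six-membered ring, so some shift is possible. The step from compound 1 to compound 4 is expected to be a 1.7-fold higher number from compound 1 to compound 4 (0.22 log units; within the scatter), that is, a small move toward weaker binding that may still fall within the scatter. Compound 4 is therefore estimated to give 20 nM in this assay, with a likely range from 5 nM to 80 nM.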

Compound 4, inhibition constant: 497 nM
For compound 4 the middle estimate is 25-fold (1.40 log units) below the measured one, outside the stated range (above it).
By their numbers in this assay, from the lowest: compounds 1 and 2 (each within the scatter of the next); then compound 4. At a limit, above all of these: compound 3.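

In this assay, within the data shown here, putting pyridin-3-yl in place of 3-methyl-1,2-oxazol-5-yl on this aromatic carbon gives a 41-fold higher number from compound 1 to compound 4 (1.62 log units; beyond the scatter) and is a large step, the only single change that can be read so far. This position therefore does not treat all aromatic rings alike: the two groups match in heavy atoms, hydrogen-bond donors and net charge, yet differ in ring size, hetero atoms and hydrogen-bond acceptors. Nothing measured here explains why this swap has such an effect.

As far as these compounds go, it remains open which of those differences matters, or whether the methyl group plays a part. A phenyl group or a 1,2-oxazol-5-yl without the methyl, placed on the otherwise unchanged compound 1, would help to separate these possibilities.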